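The source may hold more compounds than are shown below. What is called first, only, known or untested is meant among the compounds shown, and "the series" means these compounds.

Compound 1, `NC1=NC2(CCSCC2)N(OCCCOc2ccc(Cl)c(Cl)c2)C(N)=N1`, carries a 3,4-dichlorophenyl group on the ether oxygen of its side chain and rests on a core whose saturated ring contains a sulfur. In an assay on isolated protein for inhibition of Dihydrofolate reductase (Homo sapiens), read by spectrophotometry, using NADPH, with stated times of 5 s and 6 min (on this read-out higher numbers stand for weaker inhibition and lower numbers for stronger inhibition), compound 1 is recorded as "not determined" (no result reported), so there is no single number on which it can be placed. The only measured point in this series is compound 2, `COc1ccc(OCCCON2C(N)=NC(N)=NC23CCOCC3)cc1`, which differs from compound 1 both in the aryl group and in the core; in this assay compound 2 gives 11.1 nM.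

Compound 3, `NC1=NC2(CCSCC2)N(OCCCOc2ccc(Br)cc2)C(N)=N1`, is reached from compound 1 by one change, (4-bromophenyl in place of 3,4-dichlorophenyl on an oxygen on a saturated carbon). Since compound 1 has no value in this assay, the size of the step from compound 1 to compound 3 cannot be read from the numbers, and no direction beyond the scatter can be claimed for it. The expectation for compound 3 therefore rests on compound 2 alone, whose 11.1 nM is the only anchor. On that footing compound 3 is estimated at 10 nM in this assay, with an expected range from 2.5 nM to 40 nM.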

Compound 3, half-maximal inhibitory concentration: 6.46 nM
The estimate for compound 3 lay 1.5-fold (0.19 log units) above the measured number; low and high end bracket the measured number.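

Within the data shown here, compound 1 has no single number in this assay to set against compound 3, so no step between these two compounds can be read. The compounds shown leave open how 4-bromophenyl and 3,4-dichlorophenyl compare on the shared core in this assay and whether the exchange matters at all. Nothing shown offers an explanation for the result of compound 3.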